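The source may report more compounds than this note shows. Statements on the series, on what has been measured and on what is new or still open speak of the compounds shown alone.

Measured compounds in a functional assay on HEK293 cells with Glucose-dependent insulinotropic receptor (Homo sapiens) as the target, read by cAMP accumulation, with a stated time of 60 min; a lower number here means a smaller maximal response, a higher number a larger maximal response:
compound 1, `CCCc1cnc(N2CCC(C3Cc4cc(C5=CCN(S(=O)(=O)CCC)CC5)ccc4O3)CC2)nc1`, gives 107%
compound 2, `CCCc1cnc(N2CCC(C3Cc4cc(N5CCN(S(=O)(=O)CCC)CC5)ccc4O3)CC2)nc1`, gives 74%
compound 3, `CCCc1cnc(N2CCC(C3(C)Cc4cc(C5=CCN(S(=O)(=O)CCC)CC5)ccc4O3)CC2)nc1`, gives 48%

Compound 3 holds the lowest of the three numbers in this assay. Its nearest neighbour is compound 2, whose number is higher beyond the scatter, and the furthest is compound 1. Two single-point steps are known. Replacing one ring group on the aromatic carbon gave a number 33 percentage points lower from compound 1 to compound 2 (beyond the scatter). Adding a methyl on a saturated ring carbon of the shared core gave a number 59 percentage points lower from compound 1 to compound 3 (beyond the scatter).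

Compound 4, `CCCc1cnc(N2CCC(C3(C)Cc4cc(C5=CCN(S(=O)(=O)CCCCO)CC5)ccc4O3)CC2)nc1`, keeps the methyl-bearing core of compound 3 and differs from it only at the end of the sulfonyl chain: hydroxymethyl in place of hydrogen on a saturated chain carbon, three bonds along the chain from a sulfonyl sulfur. For the measured compounds named here, neither of the two measured steps touches that chain, so no step directly bears on this change; both concern the opposite end of the molecule. With nothing in the data pointing to a shift at the sulfonyl chain, the step of a number 2 percentage points higher from compound 3 to compound 4 (within the scatter) is expected to stay within the scatter. Compound 4 is therefore estimated to give 50% in this assay, with a range from 32% to 72%.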

Compound 4, largest response reached (Emax), in percent of the reference or control that the assay uses: 67%
For compound 4 the middle estimate is 17 percentage points below the measured one; the measured number falls inside the stated range.
By their numbers in this assay, from the lowest: compound 3; then compounds 4 and 2 (each within the scatter of the next); then compound 1.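

The end of the sulfonyl chain turns out not to be a silent position: in this assay, hydroxymethyl in place of hydrogen on a saturated chain carbon, three bonds along the chain from a sulfonyl sulfur, gave a number 19 percentage points higher from compound 3 to compound 4 (beyond the scatter). The earlier steps concerned only the ring group on the aromatic carbon and the methyl on the shared core, and both lowered the number, so this propyl to 4-hydroxybutyl change is the first step shown to raise it, and it does so on the methyl-bearing core. No measurement at hand accounts for this rise.

The compounds shown leave open whether the 4-hydroxybutyl chain would have a comparable effect on the core of compound 1, which carries hydrogen in place of that methyl. They also leave open whether the rise belongs to the hydroxyl group or to the longer chain alone, a question that a plain butyl chain, or a carboxylic acid or an amine at the chain end, would help to separate.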